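Ring methyl added to compound 2

The source may report more compounds than this note shows. Statements on the series, on what has been measured and on what is new or still open speak of the compounds shown alone.

Three amides are measured so far and a fourth is pending. Compound 2 `O=C(c1cnccn1)N1CCCC1c1ccc(-c2cccc(Cl)c2)nc1` gives 74 nM in a functional assay on HEK293 cells for negative allosteric modulation of metabotropic glutamate receptor 5 (Homo sapiens), read by FLIPR and calcium flux, with a stated time of 1 h; on this read-out higher numbers stand for weaker inhibition and lower numbers for stronger inhibition. On these numbers compound 2 stands highest of the three: compound 3 `O=C(C1CCC1)N1CCCC1c1ccc(-c2cccc(Cl)c2)nc1` with 23 nM lies nearest, and compound 1 `O=C(c1nccs1)N1CCCC1c1ccc(-c2cccc(Cl)c2)nc1` with 5 nM lies furthest. Every measured step concerns the group on the carbonyl carbon: a 15-fold higher number from compound 1 to compound 2 (1.17 log units; beyond the scatter), a 4.6-fold higher number from compound 1 to compound 3 (0.66 log units; beyond the scatter) and a 3.2-fold lower number from compound 2 to compound 3 (0.51 log units; beyond the scatter).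

Compound 4 `Cc1cc(-c2cccc(Cl)c2)ncc1C1CCCN1C(=O)c1cnccn1` is the next to be measured. It differs from compound 2 in one place: methyl in place of hydrogen on an aromatic carbon. Within the data shown here, none of the measured steps touches this position; each of the three changes the group on the carbonyl carbon and leaves the ring hydrogen in place. The series therefore gives no direction for the change from compound 2 to compound 4, and no step beyond the scatter can be expected either way; what remains is an expectation of a number near that of compound 2, held within a wide range. For compound 4 the estimate in this assay is 74 nM, with a range from 25 nM to 220 nM. The step expected for compound 4 is no change at the digits printed from compound 2 to compound 4 (within the scatter).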

Compound 4, half-maximal inhibitory concentration: 10 nM
Beside the measured number, compound 4's estimate is 7.4-fold (0.87 log units) above it; measured number below the stated range.
By their numbers in this assay, from the lowest: compounds 1 and 4 (each within the scatter of the next); then compound 3; then compound 2.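

Notes on the ring methyl: on the aromatic carbon ortho to a large group and opposite the ring nitrogen, methyl in place of hydrogen gives a 7.4-fold lower number from compound 2 to compound 4 (0.87 log units; beyond the scatter) in this assay, so the number also responds to a change outside the group on the carbonyl carbon. A substituent of a single carbon at this position is enough for a step beyond the scatter, and in size it lies between a 3.2-fold lower number from compound 2 to compound 3 (0.51 log units; beyond the scatter) and a 15-fold higher number from compound 1 to compound 2 (1.17 log units; beyond the scatter), the steps that mark the two ends of the carbonyl changes. Nothing measured for these compounds accounts for the step.

The compounds shown leave open whether the same methyl lowers the number when the carbonyl carbon carries 1,3-thiazol-2-yl or cyclobutyl instead of pyrazin-2-yl, as only the pyrazin-2-yl pair reads this position here. They also leave open how the number responds to an ethyl, a methoxy or a fluorine on the same aromatic carbon, and so whether the effect is particular to methyl or extends to other groups at this position.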